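Pyrazinyl in Place of Benzimidazolyl on the Chloroaryl Ring

The source may hold more compounds than are shown below. What is called first, only, known or untested is meant among the compounds shown, and "the series" means these compounds.

Compound 1 `Cc1nc(C(F)(F)F)ccc1C(=O)Nc1ccc(Cl)c(-c2nc3ccccc3[nH]2)c1` is measured in an assay on C3H 10T1/2 cells for inhibition of Sonic hedgehog protein (Mus musculus), read by a luciferase reporter (on this read-out lower numbers stand for stronger inhibition and higher numbers for weaker inhibition), where compound 1 gives 12 nM, the lowest of the two numbers recorded. Its nearest neighbour is compound 2 `Cc1nc(C(F)(F)F)ccc1C(=O)Nc1ccc(Cl)c(-n2cc3ccccc3n2)c1`, which in this assay gives 80 nM. For the measured compounds named here, the one measured step is a 6.7-fold higher number from compound 1 to compound 2 (0.82 log units; beyond the scatter). Compound 3 `Cc1nc(C(F)(F)F)ccc1C(=O)Nc1ccc(Cl)c(-c2cnccn2)c1` differs from compound 1 in a single place: pyrazin-2-yl in place of 1H-benzimidazol-2-yl on an aromatic carbon. The group that enters is smaller than the one that leaves and carries no hydrogen-bond donor. Going by the values given here, the only step that bears on this change is the exchange of the same group in compound 2, and it was a clear loss. A loss is therefore expected for compound 3 as well, and the step is estimated at a 13-fold higher number from compound 1 to compound 3 (1.10 log units; beyond the scatter). Compound 3 is expected to give about 150 nM, with a range from 30 nM to 800 nM.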

Compound 3, half-maximal inhibitory concentration: 1700 nM
Compound 3: the middle estimate sits 11-fold (1.05 log units) below what was measured; measured number above the stated range.
By their numbers in this assay, from the lowest: compound 1; then compound 2; then compound 3.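

In this assay, the change at this position, on an aromatic carbon ortho to a chloro group, proves far more costly with pyrazin-2-yl than with 2H-indazol-2-yl: replacing 1H-benzimidazol-2-yl gives a 140-fold higher number from compound 1 to compound 3 (2.15 log units; beyond the scatter), and replacing 2H-indazol-2-yl gives a 21-fold higher number from compound 2 to compound 3 (1.33 log units; beyond the scatter). Among these three compounds, the group with a single six-membered aromatic ring gives the highest number, so the position clearly distinguishes between these aromatic groups, and the one earlier step did not reveal how large the loss could become. No evidence at hand explains the size of this loss.

On these data alone, it remains open whether a plain phenyl ring or a benzoxazol-2-yl group would behave more like pyrazin-2-yl or like 1H-benzimidazol-2-yl. Also open, as far as these compounds go, is whether the loss follows the size of the group or the placing of its nitrogen atoms.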